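The compounds below may be only part of what the source reports. "The series", "measured", "known", "first", "only" and "open" are said of these compounds alone.

Three compounds have been measured in a functional assay on PC-12 cells (Rattus norvegicus) for cytotoxicity, read by MTT assay, with a stated time of 24 h, tested at 0.1 uM; a higher number here means a stronger effect of the compound at the concentration tested, a lower number a weaker effect:
compound 1 `COc1ccc(C(c2ccc(OC)cc2)N2CCN(C(=O)COc3ccc4ccccc4c3)CC2)cc1` gives 2.55%;
compound 2 `O=C(COc1ccc2ccccc2c1)N1CCN(C(c2ccc(Br)cc2)c2ccc(Br)cc2)CC1` gives 4.06%;
compound 3 `Cc1ccc(C(c2ccc(C)cc2)N2CCN(C(=O)COc3ccc4ccccc4c3)CC2)cc1` gives 4.75%.

Compound 1 holds the lowest of the three numbers, but the gaps are small: compound 2 lies closest to it, within the scatter, and compound 3, the furthest of the three, also lies within the scatter. On these numbers nothing separates the three compounds; each gives a small read-out in this assay at the concentration tested.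

The next compound, compound 4 `COc1ccc(C(c2ccc(OC)cc2)N2CCN(C(=O)COc3ccccc3C)CC2)cc1`, differs from compound 1 in one place: 2-methylphenyl in place of naphthalen-2-yl on an oxygen on a saturated carbon. For the measured compounds named here, no step between two measured compounds that differ in only one place is available, so the size of this change cannot be read from a measured pair. What the three measured compounds do show is that compounds differing elsewhere on the shared core give numbers within the scatter of one another, and none of them rises far above the scatter. The expectation for compound 4 in this assay is therefore a step of no more than the scatter, in no particular direction. Compound 4 is estimated at 3.5%, with a range from 0% to 10%. The step this estimate means is expected to be a number 1 percentage points higher from compound 1 to compound 4 (within the scatter).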

Compound 4, a percentage reported as activity, at one concentration (the size of the read-out at that concentration, not a potency): 2.45%
The estimate for compound 4 lay 1.1 percentage points above the measured number, and the stated range covers the measured number.
By their numbers in this assay, from the lowest: compounds 4, 1, 2 and 3 (each within the scatter of the next).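

Placing 2-methylphenyl in the position of naphthalen-2-yl on an oxygen on a saturated carbon gives the first single-place comparison in this series, with a number 0.1 percentage points lower from compound 1 to compound 4 (within the scatter) in this assay as its result. At this place, a group of 10 heavy atoms with 2 aromatic rings and a group of 7 heavy atoms with one aromatic ring therefore give read-outs that cannot be told apart, although this rests on a single pair on the core of compound 1. No measured evidence bears on why this change leaves the read-out within the scatter.

As far as these compounds go, it remains open whether an amine or a carboxylic acid in place of the aromatic group on this oxygen would also leave the number within the scatter of compound 1, and whether a longer chain carrying the 2-methylphenoxy group would do the same. Because the read-out comes from one concentration, these compounds also leave open how the same change would behave at higher concentrations in this assay and whether it would behave alike on the bromo or methyl compounds.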